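Triazole-linked methoxyaryl series: removal of one methoxy group

The source may hold more compounds than are shown below. What is called first, only, known or untested is meant among the compounds shown, and "the series" means these compounds.

Measured compounds:
compound 1 `COc1ccc(-n2cc(-c3ccc(OC)c(OC)c3)nn2)cc1` — > 100 nM
compound 2 `COc1ccc(-c2cn(-c3cc(OC)c(OC)c(OC)c3)nn2)cc1OC` — "not determined" (no result reported)
compound 3 `COc1ccc(-c2cn(-c3ccc(OC)cc3)nn2)cc1` — > 100 nM

The read-out is a functional assay on MDA-MB-231 cells (Homo sapiens) for cytotoxicity, read by MTT assay; on this read-out higher numbers stand for weaker inhibition and lower numbers for stronger inhibition. In this assay compound 1 gives > 100 nM, which is a limit of the assay and not a number. Compound 3 gives > 100 nM, likewise a limit. For compound 2 no result is reported: "not determined" (no result reported).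

The change from compound 1 to compound 3 is hydrogen in place of methoxy on an aromatic carbon. The step that the two limits leave unreadable from compound 1 to compound 3 cannot be read, because both ends sit at the limit of > 100 nM in this assay, at which 2 of the 3 values shown sit.

Compound 4 `COc1cc(OC)cc(-n2cc(-c3ccc(OC)c(OC)c3)nn2)c1` is not yet measured. It arises from compound 2 by hydrogen in place of methoxy on an aromatic carbon. This is the same kind of change as that from compound 1 to compound 3, but the surroundings differ: in compound 1 the methoxy that leaves sits ortho to a methoxy group and meta to a large group, whereas in compound 2 it sits ortho to two methoxy groups and para to a large group. How the core of compound 2 differs from that of compound 1 is not broken down here.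

Among the compounds with values here, no step can be read for the pair compound 2 to compound 4, since compound 2 has no value and the one measured step of the same kind is unreadable. Weak inhibition is expected, since the two measured compounds in this assay both return only a limit. For compound 4 the expected value is 400 nM, with the likely range 80 nM to 5000 nM; a limit rather than a number is the more likely outcome.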

Compound 4, half-maximal inhibitory concentration: > 1000 nM
Compound 4: only a limit was reported; the forecaster's own chance of this, stated with the estimate: 70%; at least 2.5-fold (0.39 log units) between middle value and limit.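

In this assay compound 4 gives > 1000 nM, which is a limit of the assay and not a number. No new step can be read between compound 2 and compound 4: compound 2 gives "not determined" (no result reported). The compounds shown leave open how strongly any of them acts in this assay, and whether hydrogen in place of methoxy on an aromatic carbon shifts the read-out at all.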